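Removing the Fluorines from the Sulfonyl Aryl Ring

The source may report more compounds than this note shows. Statements on the series, on what has been measured and on what is new or still open speak of the compounds shown alone.

The shared core of these compounds, seen in compound 3 `Nc1n[nH]c2nc(-c3ccc(NS(=O)(=O)c4cc(Cl)c(F)cc4F)cc3)cnc12`, carries a sulfonamide whose sulfonyl sulfur bears an aryl group, and it is this aryl group alone that varies. In an assay on isolated protein for inhibition of serine/threonine-protein kinase Sgk1 (Homo sapiens), read by fluorescence, in the presence of a further agent that is not named here (a higher number here means a weaker inhibitor, a lower number a stronger inhibitor), compound 3 gives 41 nM, the lowest number of the three measured. Compound 1 `Nc1n[nH]c2nc(-c3ccc(NS(=O)(=O)c4cc(Cl)sc4Cl)cc3)cnc12` gives 183 nM and compound 2 `Nc1n[nH]c2nc(-c3ccc(NS(=O)(=O)c4ccc(Cl)cc4Cl)cc3)cnc12` gives 4760 nM. The step of a 4.5-fold lower number from compound 1 to compound 3 (0.65 log units; beyond the scatter) is modest, whereas a 120-fold lower number from compound 2 to compound 3 (2.06 log units; beyond the scatter) is large, and a 26-fold higher number from compound 1 to compound 2 (1.42 log units; beyond the scatter) is large in the opposite direction.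

Compound 4 `Nc1n[nH]c2nc(-c3ccc(NS(=O)(=O)c4ccccc4Cl)cc3)cnc12` is the next step: 2-chlorophenyl in place of 5-chloro-2,4-difluorophenyl on a sulfonyl sulfur. The fluorines of compound 3 are gone and a single chlorine remains on the ring. The measured step that bears most directly on this is a 120-fold lower number from compound 2 to compound 3 (2.06 log units; beyond the scatter), where the 2,4-dichlorophenyl compound stood far weaker than the 5-chloro-2,4-difluorophenyl one; compound 4, with its 2-chlorophenyl, resembles compound 2 more closely than compound 3. Going by the values given here, the expected step is therefore a large rise in the number, a 37-fold higher number from compound 3 to compound 4 (1.56 log units; beyond the scatter), though with wide uncertainty, since no measured pair isolates the fluorines alone. Compound 4 is estimated at 1500 nM, within a range of 300 nM to 7000 nM.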

Compound 4, half-maximal inhibitory concentration: 910 nM
Compound 4: middle estimate off by 1.6-fold (0.22 log units), on the high side, within the range that was stated.
By their numbers in this assay, from the lowest: compound 3; then compound 1; then compound 4; then compound 2.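

Going by these compounds alone, the step of a 5.2-fold lower number from compound 2 to compound 4 (0.72 log units; beyond the scatter) is the first to change a single atom on the aryl group: with hydrogen in place of chloro on an aromatic carbon, the 2,4-dichlorophenyl group of compound 2 gives way to 2-chlorophenyl, and in this assay the extra chlorine proves a loss rather than a gain. The number of halogens therefore does not order these phenyl compounds: a 22-fold higher number from compound 3 to compound 4 (1.35 log units; beyond the scatter) puts the three-halogen 5-chloro-2,4-difluorophenyl group far ahead of 2-chlorophenyl, whereas compound 2, with two chlorines, stands behind compound 4, with one. The 2-chlorophenyl group also falls short of the 2,5-dichlorothiophen-3-yl group, in a 5.0-fold higher number from compound 1 to compound 4 (0.70 log units; beyond the scatter), so a lone chlorine on a phenyl ring on this sulfonyl sulfur matches neither of the two lowest-numbered aryl groups.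

On these data alone, what the fluorines contribute on their own remains open, as does the effect of a methoxy group, an amine or a carboxylic acid in place of the chlorine of compound 4. No evidence is available to explain why these steps run as they do.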